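Dichlorophenyl replaces dimethylaminophenyl on the saturated ring carbon

The compounds below may be only part of what the source reports. "The series", "measured", "known", "first", "only" and "open" are said of these compounds alone.

Three compounds share one core. Compound 1 `COc1cc(/C=C/C(=O)C2=C(/C=C/c3ccc(O)c(OC)c3)NC(=S)NC2c2ccc(C)cc2)ccc1O` gives 43.2% in a functional assay, with a stated time of 20 min, tested at 10 uM; on this read-out higher numbers stand for a stronger effect at the one concentration tested and lower numbers for a weaker effect; compound 2 `COc1cc(/C=C/C(=O)C2=C(/C=C/c3ccc(O)c(OC)c3)NC(=S)NC2c2ccccc2O)ccc1O` gives 60.2%; compound 3 `COc1cc(/C=C/C(=O)C2=C(/C=C/c3ccc(O)c(OC)c3)NC(=S)NC2c2ccc(N(C)C)cc2)ccc1O` gives 72%, the highest of the three, with a number 11.8 percentage points higher from compound 2 to compound 3 (beyond the scatter) and a number 28.8 percentage points higher from compound 1 to compound 3 (beyond the scatter). Compound 4 `COc1cc(/C=C/C(=O)C2=C(/C=C/c3ccc(O)c(OC)c3)NC(=S)NC2c2c(Cl)cccc2Cl)ccc1O` has not been measured. The change is 2,6-dichlorophenyl in place of 4-(dimethylamino)phenyl on a saturated ring carbon. Among the measured compounds shown here, the steps that bear on it are those at the same saturated ring carbon: a number 17 percentage points higher from compound 1 to compound 2 (beyond the scatter), a number 11.8 percentage points higher from compound 2 to compound 3 (beyond the scatter) and a number 28.8 percentage points higher from compound 1 to compound 3 (beyond the scatter). For the measured compounds named here, no measured compound carries a dichlorophenyl there, so the direction rests on compound 3 holding the top value. The expected step is a number 24 percentage points lower from compound 3 to compound 4 (beyond the scatter), a fall beyond the scatter. For compound 4 the estimate is 48%, between 28% and 68%.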

Compound 4, a percentage reported as activity, at one concentration (the size of the read-out at that concentration, not a potency): 29%
Estimate against measurement, compound 4: 19 percentage points above; the measured number falls inside the stated range.
By their numbers in this assay, from the lowest: compound 4; then compound 1; then compound 2; then compound 3.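

At this saturated ring carbon, in this assay, 2,6-dichlorophenyl gives the lowest number of the four compounds (a number 43 percentage points lower from compound 3 to compound 4 (beyond the scatter); a number 31.2 percentage points lower from compound 2 to compound 4 (beyond the scatter); a number 14.2 percentage points lower from compound 1 to compound 4 (beyond the scatter)). The floor of the series therefore no longer lies with 4-methylphenyl, so the earlier compounds had not shown the full range at this position. Nothing measured here explains the fall.

The compounds shown leave open whether a single chlorine on the phenyl ring would give a number nearer compound 4 or compound 1. They also leave open whether a morpholine in place of dimethylamino would hold the top value.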